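Phenethyl for 2-phenylethynyl on two cores

The source may hold more compounds than are shown below. What is called first, only, known or untested is meant among the compounds shown, and "the series" means these compounds.

Compound 1 `CN(C)CCC(NC(=O)C#Cc1ccccc1)c1ccc(Cl)cc1` carries a 2-phenylethynyl group on a carbonyl carbon. In a functional assay on NIH3T3 cells for agonist activity at Urotensin-2 receptor (Homo sapiens), with a stated time of 5 days (on this read-out higher numbers stand for larger maximal responses and lower numbers for smaller maximal responses), compound 1 gives 124%. Compound 2 `CN(C)CCC(NC(=O)CCc1ccccc1)c1ccc(Cl)cc1` differs from compound 1 in one place: phenethyl in place of 2-phenylethynyl on a carbonyl carbon. In this assay compound 2 gives 139%, so the step of a number 15 percentage points higher from compound 1 to compound 2 (beyond the scatter) is modest but beyond the scatter.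

Compound 3 `CN(C)CCC(NC(=O)C#Cc1ccccc1)c1ccc2ccccc2c1` keeps the 2-phenylethynyl amide on another core; how the core of compound 3 differs from that of compound 1 is not broken down here. In this assay compound 3 gives 115%; against compound 1 the two numbers lie within the scatter of each other, while the gap to compound 2 is beyond it.

Compound 4 `CN(C)CCC(NC(=O)CCc1ccccc1)c1ccc2ccccc2c1` is not yet measured. It stands to compound 3 as compound 2 stands to compound 1: phenethyl in place of 2-phenylethynyl on a carbonyl carbon. The place is described in the same words in both cases, so this is the same change, seen once before among these compounds. For the measured compounds named here, with only one prior instance, on a different core, the expectation rests on that single step. The expected step is a number 15 percentage points higher from compound 3 to compound 4 (beyond the scatter), because the same change gave a number 15 percentage points higher from compound 1 to compound 2 (beyond the scatter). Compound 4 is accordingly estimated at 130% in this assay, with the range 115% to 145% allowing for the step on the second core to come out differently from the earlier one.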

Compound 4, largest response reached (reported as efficacy), in percent of the reference or control that the assay uses: 107%
The estimate for compound 4 lay 23 percentage points above the measured number, outside the stated range (below it).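

In this assay, phenethyl in place of 2-phenylethynyl on a carbonyl carbon does not give the same result on both cores: the same change on two cores in this assay, a number 15 percentage points higher (beyond the scatter) from compound 1 to compound 2 and a number 8 percentage points lower (within the scatter) from compound 3 to compound 4, 23 percentage points apart, beyond the scatter of two such steps

On the core of compound 3 the change gives a number 8 percentage points lower from compound 3 to compound 4 (within the scatter), so the two maximal responses on this core cannot be told apart, whereas on the core of compound 1 the two responses do separate. For the compounds shown here, with only two matched pairs, this does not show which feature of the cores goes with the difference, how the change would behave on a third core, or whether either result is the more typical one, so a step seen on one core gives no reliable estimate for another.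

Still open, going by these compounds, is whether a third group on the amide carbonyl, such as a 2-phenylethenyl group or the longer 3-phenylpropyl chain, would separate the two cores in the same way. Also open, on these data alone, is whether the difference between the cores persists when a pyrrolidine ring takes the place of the dimethylamino group, which all four compounds share.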